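Moving a methoxy group on an aryl ring of a cyclic ether

The source may hold more compounds than are shown below. What is called first, only, known or untested is meant among the compounds shown, and "the series" means these compounds.

Measured so far:
- compound 1, `O[C@@H](c1ccccc1)[C@H]1CO[C@H](c2ccccc2)[C@@H](C/C=C/c2ccccn2)C1`, gives 33800 nM
- compound 2, `COc1ccc([C@H](O)[C@H]2CO[C@@H](c3ccc(OC)c(OC)c3)[C@H](C/C=C/c3ccc(OC)c(OC)c3)C2)cc1`, gives 32200 nM
- compound 3, `COc1ccc([C@H]2OC[C@H]([C@@H](O)c3ccc(OC)c(OC)c3)C[C@@H]2C/C=C/c2ccc(OC)c(OC)c2)cc1`, gives 46700 nM

These three compounds were tested in a functional assay on HeLa cells (Homo sapiens) for cytotoxicity, read by WST assay, with a stated time of 48 h; a lower number here means a stronger inhibitor, a higher number a weaker inhibitor. Compound 3 shows the highest of the three numbers, yet its gap to compound 1 and its gap to compound 2 both lie within the usual scatter, so the three cannot be told apart on the numbers alone. Compound 4, `COc1cccc([C@H]2OC[C@H]([C@@H](O)c3ccc(OC)c(OC)c3)C[C@@H]2C/C=C/c2ccc(OC)c(OC)c2)c1`, has not yet been measured. It differs from compound 3 in one place: 3-methoxyphenyl in place of 4-methoxyphenyl on a saturated ring carbon. The two share every atom and differ only in where one methoxy group sits on that aryl ring. Going by the values given here, nothing among the measured compounds shows what such a shift does, and the three measured values sit close together, so no step beyond the scatter is expected in this assay in either direction. The step from compound 3 to compound 4 is therefore estimated at a 1.0-fold lower number from compound 3 to compound 4 (0.02 log units; within the scatter). Compound 4 is expected to give about 45000 nM, within a range from 20000 nM to 100000 nM.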

Compound 4, half-maximal inhibitory concentration: 21800 nM
Beside the measured number, compound 4's estimate is 2.1-fold (0.31 log units) above it, and the stated range covers the measured number.
By their numbers in this assay, from the lowest: compounds 4, 2, 1 and 3 (each within the scatter of the next, the first and the last beyond it).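

Among the earlier compounds, no two differed in one place, so none showed what a single change does. In this assay, 3-methoxyphenyl in place of 4-methoxyphenyl gives a 2.1-fold lower number from compound 3 to compound 4 (0.33 log units; beyond the scatter) and provides the first such reading. The two compounds have the same atoms and differ only in where one methoxy group sits on the aryl ring, so this single pair shows that the location of that group on this ring, at a saturated ring carbon next to the ring oxygen, can shift the number beyond the usual scatter.

From the compounds shown here alone, it remains open whether an amine or a chlorine atom in place of the methoxy group on this aryl ring would move the number further in either direction. No measurement shown here explains why this shift lowers the number.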